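A Single Bromo Removed from Compound 3

A few compounds are considered here, and "the series" means these few. Any claim that something is new, unique, unknown or untested is made for them only; others in the source may bear on it.

Compound 1 `COc1ccc(OC)c(/C=N/NC(=O)Nc2ccc(Oc3ccnc(-c4nncn4CCN(C)C)c3)c(F)c2)c1`: 1950 nM in a functional assay on A549 cells (Homo sapiens) for cytotoxicity, read by MTT assay, with a stated time of 72 h; a higher number here means a weaker inhibitor, a lower number a stronger inhibitor
Compound 2 `CN(C)CCn1cnnc1-c1cc(Oc2ccc(NC(=O)N/N=C/c3ccc(O)c(O)c3)cc2F)ccn1`: > 100000 nM
Compound 3 `CN(C)CCn1cnnc1-c1cc(Oc2ccc(NC(=O)N/N=C/c3cc(Br)c(O)c(Br)c3)cc2F)ccn1`: > 100000 nM

The three compounds share one core and differ only in the aryl group on the carbon with a double bond to nitrogen. Compound 1, with its 2,5-dimethoxyphenyl, is the only one of the three with a measured number in this assay. The value of compound 2 is a limit of this assay, not a number. The value of compound 3 is likewise a limit. The steps from the measured compound are an at least 51-fold higher number from compound 1 to compound 2 (1.70 log units; beyond the scatter) and an at least 51-fold higher number from compound 1 to compound 3 (1.70 log units; beyond the scatter), whereas a step that the two limits leave unreadable from compound 2 to compound 3. Compound 3 therefore stands at the limit of > 100000 nM in this assay, at which 2 of the 3 values shown sit, and nothing in the shown data places it relative to compound 2.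

Compound 4 `CN(C)CCn1cnnc1-c1cc(Oc2ccc(NC(=O)N/N=C/c3ccc(O)c(Br)c3)cc2F)ccn1` is the next step from compound 3: hydrogen in place of bromo on an aromatic carbon. The step bearing on it is that from compound 2 to compound 3, where both ends sit at the limit and the size cannot be read; the steps from compound 1 show only that both hydroxyphenyl variants lie far weaker. Compound 4 keeps one bromo and the hydroxy group, so it is expected to remain at or near the limit, with a number no higher from compound 3 to compound 4 (the limit leaves the size open) expected to lie within the scatter. Compound 4 is estimated at 100000 nM, between 30000 nM and 300000 nM.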

Compound 4, half-maximal inhibitory concentration: 1370 nM
Compound 4: middle estimate off by 73-fold (1.86 log units), on the high side, and the stated range ends above it.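

In this assay, hydrogen in place of bromo on an aromatic carbon ortho to a hydroxy group gives an at least 72-fold lower number from compound 3 to compound 4 (1.86 log units; beyond the scatter), which shows that this single position on the ring can decide whether the compound leaves the limit. Bromo in place of hydroxy on an aromatic carbon gives an at least 72-fold lower number from compound 2 to compound 4 (1.86 log units; beyond the scatter), while a 1.4-fold lower number from compound 1 to compound 4 (0.15 log units; within the scatter) puts the 3-bromo-4-hydroxyphenyl level with the 2,5-dimethoxyphenyl, so a hydroxyphenyl group as such does not hold a compound at the limit. Compound 3 remains at a limit and not a number, and so does compound 2: the limit of > 100000 nM in this assay, at which 2 of the 4 values shown sit.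

From the compounds shown here alone, it remains open whether chloro, methyl or methoxy at this position, ortho to the hydroxy group, would keep compound 4 in its range or return the compound to the limit. The shown compounds also leave open what the remaining bromo contributes, since the plain 4-hydroxyphenyl does not appear among them, and whether the hydroxy group itself could give way to an amine or a methoxy group.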